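The source may hold more compounds than are shown below. What is called first, only, known or untested is meant among the compounds shown, and "the series" means these compounds.

Three compounds share one core and differ only in the aromatic ring attached to the carbonyl carbon of the amide. In a functional assay on A549 cells (Homo sapiens) for antiproliferative activity, read by CCK-8 assay, with a stated time of 72 h (a higher number here means a weaker inhibitor, a lower number a stronger inhibitor), compound 1 `O=C(Nc1cccc(-c2oc3cc(-c4ccc(F)cc4)ccc3c(=O)c2O)c1)c1ccccc1F` gives 4410 nM, compound 2 `O=C(Nc1cccc(-c2oc3cc(-c4ccc(F)cc4)ccc3c(=O)c2O)c1)c1ccc(F)cc1F` gives 20500 nM, and compound 3 `Cc1cc(C(=O)Nc2cccc(-c3oc4cc(-c5ccc(F)cc5)ccc4c(=O)c3O)c2)ccc1F` gives 11500 nM. Compound 2 has the highest number of the three: the gap to compound 3 is within the scatter, while a 4.6-fold higher number from compound 1 to compound 2 (0.67 log units; beyond the scatter) is beyond it. Compound 4 `O=C(Nc1cccc(-c2oc3cc(-c4ccc(F)cc4)ccc3c(=O)c2O)c1)c1ccc(Cl)nc1` differs from compound 2 by 6-chloropyridin-3-yl in place of 2,4-difluorophenyl on a carbonyl carbon. For the measured compounds named here, no measured step covers this exact change; the nearest, a 1.8-fold lower number from compound 2 to compound 3 (0.25 log units; within the scatter) and a 2.6-fold higher number from compound 1 to compound 3 (0.42 log units; beyond the scatter), show that swapping this ring moves this assay only modestly. A modest fall is therefore expected, a 2.3-fold lower number from compound 2 to compound 4 (0.36 log units; beyond the scatter), so compound 4 is estimated at 9000 nM, likely between 3000 nM and 30000 nM.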

Compound 4, half-maximal inhibitory concentration: 3580 nM
Compound 4: the middle estimate sits 2.5-fold (0.40 log units) above what was measured; the measured number falls inside the stated range.
By their numbers in this assay, from the lowest: compounds 4 and 1 (each within the scatter of the next); then compounds 3 and 2 (each within the scatter of the next).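

Among the rings shown on this carbonyl carbon, 6-chloropyridin-3-yl is the only one with a hetero atom, and in this assay it holds level with the 2-fluorophenyl ring, with a 1.2-fold lower number from compound 1 to compound 4 (0.09 log units; within the scatter). The same ring gives clear gains over the other two, with a 5.7-fold lower number from compound 2 to compound 4 (0.76 log units; beyond the scatter) and a 3.2-fold lower number from compound 3 to compound 4 (0.51 log units; beyond the scatter), so a benzene ring is not required here. Nothing shown explains these shifts. As far as these compounds go, compound 4 brings in the ring nitrogen and the chlorine together, so the share of each stays open. A plain pyridin-3-yl ring or a 6-aminopyridin-3-yl ring would help to separate them.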